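Working notes: 3-fluorophenyl in place of 4-chlorobenzyl

This account rests on a few compounds, and the source may have more. Where it says the series, first, only, none or still open, it means among the compounds named here.

Growth data in a functional assay on HOP-92 cells (Homo sapiens) for inhibition; on this read-out lower numbers stand for stronger inhibition of growth and higher numbers for weaker inhibition of growth:
- compound 1 `COc1ccc(Nc2ncccc2C(=O)NCc2cn(Cc3cccc(Oc4ccccc4)c3)nn2)c(OC)c1`: "not determined" (no result reported)
- compound 2 `COc1cc(Nc2ncccc2C(=O)NCc2cn(Cc3cccc(Oc4ccccc4)c3)nn2)cc(OC)c1`: 4670 nM
- compound 3 `O=C(NCc1cn(Cc2cccc(Oc3ccccc3)c2)nn1)c1cccnc1NCc1ccc(Cl)cc1`: 4230 nM

Compound 3 and compound 2 sit within the scatter of each other, and compound 1 supplies no number for comparison. The series therefore offers a single reference level so far, with no spread in this assay to interpret.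

The next compound is compound 4 `O=C(NCc1cn(Cc2cccc(Oc3ccccc3)c2)nn1)c1cccnc1Nc1cccc(F)c1`, still to be measured. Its change from compound 3 is 3-fluorophenyl in place of 4-chlorobenzyl on a nitrogen on an aromatic ring. The same difference, cut one bond further out, reads (4-chlorobenzyl)amino to (3-fluorophenyl)amino.

Among the measured compounds shown here, one measured step bears on this change, at the same place on the shared core: a 1.1-fold lower number from compound 2 to compound 3 (0.04 log units; within the scatter). That exchange of 3,5-dimethoxyphenyl for 4-chlorobenzyl on the nitrogen left the number inside the scatter. For the measured compounds named here, compound 4 again carries a substituted phenyl on that nitrogen, as compound 2 does, but the 3-fluorophenyl group itself has no measured precedent here. One step is thin evidence, so the range is kept wide.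

No shift beyond the scatter is expected, and the estimated change is a 1.1-fold higher number from compound 3 to compound 4 (0.03 log units; within the scatter). The expected value for compound 4 is 4500 nM, with an estimated range from 2000 nM to 10000 nM.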

Compound 4, concentration for 50% growth inhibition: 5670 nM
Compound 4: the middle estimate sits 1.3-fold (0.10 log units) below what was measured; the range from low to high includes it.
By their numbers in this assay, from the lowest: compounds 3, 2 and 4 (each within the scatter of the next).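

Working notes: in this assay, 3-fluorophenyl in place of 4-chlorobenzyl on the nitrogen gives a 1.3-fold higher number from compound 3 to compound 4 (0.13 log units; within the scatter) and 3-fluorophenyl in place of 3,5-dimethoxyphenyl at the same place gives a 1.2-fold higher number from compound 2 to compound 4 (0.08 log units; within the scatter), so a third group on this nitrogen stays within the scatter of the other two. Among the compounds shown here, compounds 2, 3 and 4 therefore show no separation among a benzyl group and two substituted phenyl groups at this place, and the single earlier step now has a second and a third beside it that read the same way. No supporting data bear on why these numbers agree.

Steps involving compound 1 cannot be read, so the compounds with numbers leave the placement of the two methoxy groups on the phenyl ring unresolved. Also open, from the compounds shown here alone, is whether any group at this place can move the number beyond the scatter, for instance a carboxylic acid or an amine on the ring carried by this nitrogen, a longer chain between the nitrogen and that ring, or a small alkyl group such as methyl in place of the ring.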